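Replacing the Ethynyl Group of Compound 1: An Expected Inhibition

A few compounds are considered here, and "the series" means these few. Any claim that something is new, unique, unknown or untested is made for them only; others in the source may bear on it.

Of the compounds shown here, two sharing a core have been tested in an assay on isolated protein for inhibition of Aromatase (Homo sapiens), read by fluorescence, using NADPH, with a stated time of 30 min, tested at 50 uM; on this read-out lower numbers stand for less inhibition and higher numbers for more inhibition at the one concentration tested (going by the name of the read-out). Compound 1 `C#Cc1c(-c2ccccc2)[nH]c2ccccc12` carries an ethynyl group and gives 88%, the highest of the two numbers. Compound 2 `Cc1ccc2cc(-c3ccccc3)[nH]c2c1` gives 32.4%, a number that lies well below compound 1, beyond the usual scatter of the measurement. Compound 3 `CO/N=C/c1c(-c2ccccc2)[nH]c2ccccc12` has not been measured. It differs from compound 1 in one place: a group of 4 heavy atoms (2 carbon, 1 nitrogen, 1 oxygen; no ring) in place of a group of 2 heavy atoms (2 carbon; no ring), on an aromatic carbon. The entering group sits on an aromatic carbon of a five-membered aromatic ring with 1 nitrogen, part of a fused or bridged system of two rings. Going by the values given here, no measured pair shows the effect of such a change, so the expectation rests on compound 1 alone. A moderate loss is expected, so that a number 18 percentage points lower from compound 1 to compound 3 (beyond the scatter) points downward, because compound 1 already stands at 88% and leaves little room upward. Compound 3 is therefore estimated at 70%, within a range from 40% to 90%.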

Compound 3, a percentage reported as inhibition, at one concentration (the size of the read-out at that concentration, not a potency): 24.7%
Beside the measured number, compound 3's estimate is 45.3 percentage points above it, and the stated range ends above it.
By their numbers in this assay, from the lowest: compounds 3 and 2 (each within the scatter of the next); then compound 1.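

In this assay, going by these compounds alone, putting the new group of four heavy atoms in place of the ethynyl group gives a number 63.3 percentage points lower from compound 1 to compound 3 (beyond the scatter) on the same aromatic carbon, the first direct reading of a change at this position. The high inhibition of compound 1 therefore does not survive every open-chain replacement here, so this position clearly matters for the read-out. The two groups differ at once in size, in the kind of bond outside the rings and in hydrogen-bond acceptors, and nothing available explains the drop.

From the compounds shown here alone, it remains open whether a nitrile, which like ethynyl has a triple bond, would keep inhibition closer to that of compound 1. A longer chain such as propynyl, or a simple methyl, would help show which feature of the ethynyl group counts.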